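A few compounds are considered here, and "the series" means these few. Any claim that something is new, unique, unknown or untested is made for them only; others in the source may bear on it.

The assay in question is a functional assay on K562 cells (Homo sapiens) for cytotoxicity, read by sulforhodamine B assay, with a stated time of 48 h; a lower number here means that less compound is tolerated, a higher number that more compound is tolerated. Compound 1, `ClCc1ccc(Cn2cnc3c(Cl)ncnc32)cc1`, gives > 100000 nM there, which is a limit of the assay rather than a number. Compound 3, `ClCc1ccccc1Cn1cnc2ncnc(Cl)c21`, gives 83200 nM. Compound 2, `ClCc1cccc(Cn2cnc3c(Cl)nc(Cl)nc32)c1`, gives > 100000 nM, again only a limit. Among the measured compounds shown here, compound 2 thus stands at the limit of > 100000 nM in this assay, at which 2 of the 3 values shown sit, with no measured number of its own and no measured step leading away from it.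

The compound not yet measured is compound 4, `Nc1nc(Cl)c2ncn(Cc3cccc(CCl)c3)c2n1`. It differs from compound 2 in one place: amino in place of chloro on an aromatic carbon. For the measured compounds named here, no pair of measured compounds shares this change, so the set holds nothing that shows its effect on this assay. With compound 2 sitting at the limit of > 100000 nM in this assay, at which 2 of the 3 values shown sit, and no measured number among the three compounds standing far from that limit, the step is expected to be a number no higher from compound 2 to compound 4 (the limit leaves the size open), nothing beyond the usual scatter and in no particular direction. Compound 4 is accordingly estimated at 100000 nM, in a range from 40000 nM to 300000 nM, and will most probably again be reported only as a limit.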

Compound 4, concentration lethal to 50% of the cells: > 100000 nM
Compound 4 was reported as a limit; the forecaster's own chance of this, stated with the estimate: 60%; the middle value sits exactly at the limit.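

In this assay compound 4 gives > 100000 nM, which is a limit and not a number. Compound 2 also has only a limit, so no step can be read between compound 2 and compound 4. The compounds shown leave open what amino in place of chloro on an aromatic carbon does in this assay.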